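The source may report more compounds than this note shows. Statements on the series, on what has been measured and on what is new or still open speak of the compounds shown alone.

Measured compounds:
- compound 1, `Cc1cnc(Nc2ccc(C#N)cc2)nc1Nc1c(F)cc(-c2cncc(C(F)(F)F)c2)cc1F`, 8200 nM
- compound 2, `Cc1cnc(Nc2ccc(C#N)cc2)nc1Nc1c(F)cc(-c2cncc(C#N)c2)cc1F`, 50000 nM
- compound 3, `Cc1cc(-c2cc3ccccc3s2)cc(C)c1Nc1ccnc(Nc2ccc(C#N)cc2)n1`, 138000 nM

These three compounds were measured in a toxicity assay on MT4 cells (Homo sapiens) for cytotoxicity, read by MTT assay, with a stated time of 5 days; on this read-out lower numbers stand for higher toxicity in this test and higher numbers for lower toxicity in this test. Compound 3 gives the highest number of the three, and so the lowest toxicity in this test; its nearest neighbour is compound 2, and compound 1 stands furthest away with a much lower number.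

Compound 4, `Cc1cc(-c2cc(F)nc(F)c2)cc(C)c1Nc1ccnc(Nc2ccc(C#N)cc2)n1`, is the unmeasured compound. Compared with compound 3 the change is 2,6-difluoropyridin-4-yl in place of 1-benzothiophen-2-yl on an aromatic carbon. The pendant group on the shared core is swapped for a smaller ring that carries two fluorine atoms, while the rest of the molecule stays the same.

Going by the values given here, only one measured step exists, and it concerns a different pair: a 6.1-fold higher number from compound 1 to compound 2 (0.79 log units; beyond the scatter). That step swaps one small group for another on a pendant ring and moves the number by a modest amount. It does not mirror the change from compound 3 to compound 4, which replaces the whole pendant ring. So the guidance is weak, and there is no direct basis for expecting a large move in either direction in this assay.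

Compound 4 is therefore expected to stay close to compound 3, as a 1.4-fold lower number from compound 3 to compound 4 (0.14 log units; within the scatter), with an estimate of 100000 nM and a range from 30000 nM to 300000 nM.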

Compound 4, half-maximal cytotoxic concentration: 6300 nM
Compound 4: middle estimate off by 16-fold (1.20 log units), on the high side; measured number outside the range, below it.
By their numbers in this assay, from the lowest: compounds 4 and 1 (each within the scatter of the next); then compound 2; then compound 3.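

In this assay, replacing 1-benzothiophen-2-yl with 2,6-difluoropyridin-4-yl on this aromatic carbon, meta to two methyl groups, gives a 22-fold lower number from compound 3 to compound 4 (1.34 log units; beyond the scatter), so a lower number here means higher toxicity in this test. The earlier step changed only a small group on a pendant ring, whereas this one shows that exchanging the whole pendant ring at this position can move the number a long way, even though the group leaving has 9 heavy atoms and the group entering has 8, and both have 0 hydrogen-bond donors, 1 hydrogen-bond acceptor and no net charge. Nothing measured here explains why the two groups behave so differently in this test.

The compounds shown leave open which part of the change goes with the lower number: the loss of the sulfur-containing pair of rings, the ring nitrogen or the two fluorine atoms. A plain phenyl ring, an unsubstituted pyridin-4-yl ring or a pyridin-4-yl ring carrying an amine at this position would help separate these parts, and none of them is among the compounds shown.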